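Replacing 4-chlorophenyl with 3-methylphenyl on a shared core

A few compounds are considered here, and "the series" means these few. Any claim that something is new, unique, unknown or untested is made for them only; others in the source may bear on it.

Compound 1 `CC1(C)[C@H]2CC[C@]1(C)N(Cc1cn(-c3ccccc3F)nn1)C(=O)C2`: 60 nM
Compound 2 `CC1(C)[C@H]2CC[C@]1(C)N(Cc1cn(-c3ccccc3)nn1)C(=O)C2`: 90 nM
Compound 3 `CC1(C)[C@H]2CC[C@]1(C)N(Cc1cn(-c3ccc(Cl)cc3)nn1)C(=O)C2`: 90 nM

In a functional assay on HepG2 cells (Homo sapiens) for inhibition, read by MTT assay, with a stated time of 24 h (a lower number here means a stronger inhibitor, a higher number a weaker inhibitor), compound 3, at 90 nM, stands level with compound 2, and compound 1 lies within the scatter of both. The next molecule, compound 4 `Cc1cccc(-n2cc(CN3C(=O)C[C@@H]4CC[C@@]3(C)C4(C)C)nn2)c1`, has 3-methylphenyl in place of 4-chlorophenyl on an aromatic nitrogen.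

Among the measured compounds shown here, three measured steps bear on this change, since each alters the same aromatic group. Putting hydrogen in place of fluoro gave a 1.5-fold higher number from compound 1 to compound 2 (0.18 log units; within the scatter). Putting chloro in place of hydrogen gave no change at the digits printed from compound 2 to compound 3 (within the scatter). Putting 4-chlorophenyl in place of 2-fluorophenyl gave a 1.5-fold higher number from compound 1 to compound 3 (0.18 log units; within the scatter). All three are small, but none of these compounds carries a methyl group, so that group remains untested here. No step beyond the scatter is therefore expected in this assay, and no direction can be favoured with confidence. The expected change is a 1.1-fold lower number from compound 3 to compound 4 (0.02 log units; within the scatter). For compound 4, the estimated value is 85 nM, with an expected range from 40 nM to 180 nM.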

Compound 4, half-maximal inhibitory concentration: 300 nM
The estimate for compound 4 lay 3.5-fold (0.55 log units) below the measured number, and the stated range ends below it.
By their numbers in this assay, from the lowest: compounds 1, 2 and 3 (each within the scatter of the next); then compound 4.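

In this assay, among the compounds shown here, this aromatic group turns out not to be indifferent: 3-methylphenyl in place of 4-chlorophenyl gave a 3.3-fold higher number from compound 3 to compound 4 (0.52 log units; beyond the scatter) and so moved the number beyond the scatter, which no earlier step had done. Adding a methyl group to this aromatic group gave a 3.3-fold higher number from compound 2 to compound 4 (0.52 log units; beyond the scatter) and 3-methylphenyl in place of 2-fluorophenyl gave a 5.0-fold higher number from compound 1 to compound 4 (0.70 log units; beyond the scatter) while the fluoro and chloro changes among compounds 1, 2 and 3 stayed within the scatter. Nothing shown here accounts for this difference.

The compounds shown leave open whether the higher number belongs to the methyl group itself or to where it sits on the ring. They also leave open what an ethyl, a methoxy group, an amine or a carboxylic acid on that ring would do.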